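Swapping the hydroxyphenyl for a dichlorophenyl

The source may hold more compounds than are shown below. What is called first, only, known or untested is meant among the compounds shown, and "the series" means these compounds.

In a functional assay on HCT-116 cells (Homo sapiens) for antiproliferative activity, read by MTT assay, with a stated time of 72 h (on this read-out higher numbers stand for weaker inhibition and lower numbers for stronger inhibition), the two measured compounds read as follows.

Compound 1 `Nc1nc(N)c2cc(CSC(=S)N3CCN(c4ccccc4)CC3)ccc2n1` gives 4120 nM
Compound 2 `Nc1nc(N)c2cc(CSC(=S)N3CCN(c4ccc(O)cc4)CC3)ccc2n1` gives 5980 nM

Compound 2, at 5980 nM, cannot be told apart from compound 1, so neither can be ranked above the other. The next compound, compound 3 `Nc1nc(N)c2cc(CSC(=S)N3CCN(c4ccc(Cl)c(Cl)c4)CC3)ccc2n1`, carries 3,4-dichlorophenyl in place of 4-hydroxyphenyl on an amine nitrogen in a ring. Going by the values given here, only one measured step bears on this change, and it alters the same aryl group: hydroxy in place of hydrogen on an aromatic carbon, a 1.5-fold higher number from compound 1 to compound 2 (0.16 log units; within the scatter). Among the compounds with values here, no measured compound carries chlorine, so this guide is a thin one. Resting on that small step between compound 1 and compound 2, no shift beyond the scatter is expected in this assay. The estimated step is a 1.5-fold lower number from compound 2 to compound 3 (0.17 log units; within the scatter). For compound 3 the expected value is 4000 nM, with an estimated range of 1500 nM to 10000 nM.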

Compound 3, half-maximal inhibitory concentration: 6680 nM
Compound 3: middle estimate off by 1.7-fold (0.22 log units), on the low side, and the stated range covers the measured number.
By their numbers in this assay, from the lowest: compounds 1, 2 and 3 (each within the scatter of the next).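

In this assay, the change to 3,4-dichlorophenyl gives a 1.1-fold higher number from compound 2 to compound 3 (0.05 log units; within the scatter) and, measured against the unsubstituted phenyl, a 1.6-fold higher number from compound 1 to compound 3 (0.21 log units; within the scatter) in the same series. The aryl group on this ring amine nitrogen has now carried no substituent, a hydroxy group and two chlorine atoms, and none of the three compounds stands beyond the scatter of the others, so removing the hydrogen-bond donor and acceptor of 4-hydroxyphenyl while adding two chlorines gives no separable reading here. No measurement of any property of these groups bears on this result.

On these data alone, whether a single chlorine, a carboxylic acid or an amine on the phenyl ring would move the number beyond the scatter remains open. So does whether a benzyl group or a pyridine ring in place of the phenyl would do so.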